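The source may hold more compounds than are shown below. What is called first, only, known or untested is meant among the compounds shown, and "the series" means these compounds.

Three compounds of the series have a solubility reading in a physicochemical assay for solubility; a higher number here means a more soluble compound, a lower number a less soluble compound. Compound 1 `CNC(=O)c1cc(C(=O)NC2CCC2)cn(Cc2ccncc2)c1=O` sits at a limit of the assay, >= 118 ug/mL. Compound 3 `CCNC(=O)c1cc(C(=O)NC)c(=O)n(Cc2ccccc2)c1` also sits at a limit of the assay, >= 144 ug/mL. Among the compounds with values here, compound 2 `CNC(=O)c1cc(C(=O)NC2CC2)cn(Cc2cccc3[nH]ccc23)c1=O` is the one member with a full number in this assay, 78 ug/mL. With two of the three readings standing at a limit of the assay, no ordering among the three can be drawn from them.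

Compound 4 `CNC(=O)c1cc(C(=O)NC2CC2)cn(Cc2cccc3occc23)c1=O` has not been measured. It differs from compound 2 in a single place: 1-benzofuran-4-yl in place of 1H-indol-4-yl on a saturated chain carbon bound to an aromatic nitrogen. Within the data shown here, no step between two measured compounds is available to gauge a change of this kind, so its size cannot be read from the series. The expected step, a 1.6-fold lower number from compound 2 to compound 4 (0.19 log units; within the scatter), is taken to be modest and downward, close to the usual scatter. Compound 4 is estimated at 50 ug/mL, with a range from 20 ug/mL to 120 ug/mL.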

Compound 4, solubility: >= 110 ug/mL
Compound 4 ended at the assay's limit; the forecaster's own chance of this, stated with the estimate: 10%; middle value at least 2.2-fold (0.34 log units) away from the limit.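

In this assay, 1-benzofuran-4-yl in place of 1H-indol-4-yl on a saturated chain carbon bound to an aromatic nitrogen gives an at least 1.4-fold higher number from compound 2 to compound 4 (0.14 log units; that floor lies within the scatter) as the first step readable at this place. Compound 4 reads >= 110 ug/mL and that is a limit, so only a floor on the step is known. Trading the hydrogen-bond donor of 1H-indol-4-yl for the acceptor of 1-benzofuran-4-yl brings no lower number here.

From the compounds shown here alone, the full size of this step stays open. Also open, going by these compounds, is how far the number would move with an amine or a carboxylic acid at this place.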